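Extending a chain versus extending an ether on the ring

The compounds below may be only part of what the source reports. "The series", "measured", "known", "first", "only" and "open" are said of these compounds alone.

Three amides were tested in an assay on microsomes from intestine for inhibition of acyl-CoA:cholesterol acyltransferase (Oryctolagus cuniculus); a higher number here means a weaker inhibitor, a lower number a stronger inhibitor. Compound 1 `CCCCCCCC(C)(C)C(=O)Nc1c(OC)cc(OC)cc1OC` gives 180 nM. Compound 2 `CCCCCCCCC(C)(C)C(=O)Nc1c(OC)cc(OC)cc1OC` is the same molecule with one more carbon on its chain; in this assay compound 2 gives 59 nM. This step, (methyl in place of hydrogen on a saturated chain carbon, eight bonds along the chain from a carbonyl carbon), produced a 3.1-fold lower number from compound 1 to compound 2 (0.48 log units; beyond the scatter).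

Compound 3 `CCCCCCCCCCC(C)(C)C(=O)Nc1c(C)cccc1OC` carries a different core, and the difference between the two cores is not broken down here. In this assay compound 3 gives 210 nM, which sits within the usual scatter of the number for compound 1.

Compound 4 `CCCCCCCCCCC(C)(C)C(=O)Nc1c(C)cccc1OCC` has not yet been measured. It differs from compound 3 by methyl in place of hydrogen on a saturated chain carbon bound to an oxygen on an aromatic ring. For the measured compounds named here, this is the same kind of change as the one between compound 1 and compound 2, a single added carbon, but not the same change: there the methyl entered on a saturated chain carbon, eight bonds along the chain from a carbonyl carbon, whereas here it enters on a saturated chain carbon bound to an oxygen on an aromatic ring. Going by the values given here, the only measured step for this kind of change is the one from compound 1 to compound 2, and it was made at a different place, so it is a weak guide. The step from compound 3 to compound 4 is therefore expected to be smaller, roughly a 1.4-fold lower number from compound 3 to compound 4 (0.15 log units; within the scatter). Compound 4 is estimated to give about 150 nM in this assay, plausibly between 60 nM and 400 nM.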

Compound 4, half-maximal inhibitory concentration: 180 nM
Beside the measured number, compound 4's estimate is 1.2-fold (0.08 log units) below it, and the stated range covers the measured number.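

In this assay, turning the methoxy of compound 3 into an ethoxy gives a 1.2-fold lower number from compound 3 to compound 4 (0.07 log units; within the scatter), so this added carbon leaves no change that can be told apart from repeated measurement. The earlier single-carbon step, made on a saturated chain carbon eight bonds along the chain from a carbonyl carbon, looks larger, yet the two steps cannot be called different: the same change on two cores in this assay, a 3.1-fold lower number (0.48 log units; beyond the scatter) from compound 1 to compound 2 and a 1.2-fold lower number (0.07 log units; within the scatter) from compound 3 to compound 4, 2.6-fold (0.42 log units) apart, within the scatter of two such steps. For the compounds shown here, this does not show that an added carbon does the same thing on every core, nor that the core changes its effect, since there is only one step on each core and the place of the added carbon changes along with the core.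

Still open, from the compounds shown here alone, is whether methoxy to ethoxy on the core of compound 1 would give a step like the one seen here, a comparison that would hold the place of the change fixed while the core differs. Also open, going by these compounds, is whether a propoxy group or a longer ether in that same place, on the core of compound 3, would move the number beyond the scatter, which a single added carbon does not do here.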